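Notes on sulfoxide isothiocyanates: the furan-2-yl step

The source may report more compounds than this note shows. Statements on the series, on what has been measured and on what is new or still open speak of the compounds shown alone.

Measured in a functional assay on SH-SY5Y cells (Homo sapiens) for cytotoxicity, read by MTT assay, with a stated time of 72 h; a higher number here means a weaker inhibitor, a lower number a stronger inhibitor:
- compound 1 `CC[S+]([O-])CCCCN=C=S`: 9810 nM
- compound 2 `CCC[S+]([O-])CCCCN=C=S`: 7660 nM
- compound 3 `CC(C)C[S+]([O-])CCCCN=C=S`: 5700 nM

Compound 3 stands within the scatter of both other compounds, as shown by a 1.7-fold lower number from compound 1 to compound 3 (0.24 log units; within the scatter) and a 1.3-fold lower number from compound 2 to compound 3 (0.13 log units; within the scatter). Going on to compound 4 `[O-][S+](CCCCN=C=S)Cc1ccco1` places furan-2-yl in place of isopropyl on a saturated chain carbon bound to a sulfur. The closest evidence is a 1.7-fold lower number from compound 1 to compound 3 (0.24 log units; within the scatter), a change at that same place, and a 1.3-fold lower number from compound 1 to compound 2 (0.11 log units; within the scatter) is similarly small. For the measured compounds named here, no measured compound carries a ring there, so this evidence is limited. No step beyond the scatter is expected, in either direction. The estimate is a 1.1-fold higher number from compound 3 to compound 4 (0.06 log units; within the scatter). Compound 4 is expected at 6500 nM, with an estimated range of 3200 nM to 13000 nM.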

Compound 4, half-maximal inhibitory concentration: 7790 nM
For compound 4 the middle estimate is 1.2-fold (0.08 log units) below the measured one, within the range that was stated.
By their numbers in this assay, from the lowest: compounds 3, 2, 4 and 1 (each within the scatter of the next).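

For the compounds shown here, at the saturated chain carbon bound to a sulfur, a ring now enters for the first time: in this assay, furan-2-yl stays within the scatter of all three earlier groups (a 1.4-fold higher number from compound 3 to compound 4 (0.14 log units; within the scatter)), (a 1.0-fold higher number from compound 2 to compound 4 (0.01 log units; within the scatter)) and (a 1.3-fold lower number from compound 1 to compound 4 (0.10 log units; within the scatter)). Among these compounds, then, neither the five-membered aromatic ring nor the added hydrogen-bond acceptor brings a step beyond the scatter at this place. Nothing available gives a reason for these values.

Going by these compounds, whether a phenyl ring, an amine or a carboxylic acid at this place would bring a step beyond the scatter remains open.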